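A methyl for a fluoro on the shared core

The source may report more compounds than this note shows. Statements on the series, on what has been measured and on what is new or still open speak of the compounds shown alone.

In a functional assay on COLO 205 cells (Homo sapiens) for inhibition, read by MTT assay, with a stated time of 48 h (on this read-out higher numbers stand for weaker inhibition and lower numbers for stronger inhibition), compound 1 (`COc1cc(C(=O)/C=C/c2cccc(O)c2)cc(OC)c1OC`) gives 49000 nM and compound 2 (`COc1cc(C(=O)/C=C/c2ccc(F)cc2)cc(OC)c1OC`) gives 25700 nM. Within the data shown here, the single measured step, a 1.9-fold lower number from compound 1 to compound 2 (0.28 log units; within the scatter), lies within the scatter, so compound 2 stands level with compound 1. Compound 3 (`COc1cc(C(=O)/C=C/c2ccc(C)cc2)cc(OC)c1OC`) carries methyl in place of fluoro on an aromatic carbon, para to a large group: methyl in place of fluoro on an aromatic carbon. Among the measured compounds shown here, no measured step tests this exchange, and the one available step bears on it only indirectly. The expected change is therefore none beyond the scatter, with an estimated 1.0-fold lower number from compound 2 to compound 3 (0.01 log units; within the scatter). Compound 3 is expected at 25000 nM, with an estimated range of 10000 nM to 60000 nM.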

Compound 3, half-maximal inhibitory concentration: 41500 nM
The estimate for compound 3 lay 1.7-fold (0.22 log units) below the measured number; the measured number falls inside the stated range.
By their numbers in this assay, from the lowest: compounds 2, 3 and 1 (each within the scatter of the next).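

Methyl and fluoro at this place on the aromatic ring cannot be told apart in this assay: the exchange gives a 1.6-fold higher number from compound 2 to compound 3 (0.21 log units; within the scatter). The 4-methylphenyl group likewise stands level with the 3-hydroxyphenyl group, with a 1.2-fold lower number from compound 1 to compound 3 (0.07 log units; within the scatter), so no change among these three compounds moves the number beyond the scatter. No evidence is available that bears on this result. Open, from the compounds shown here alone, is whether an amine or a carboxylic acid on that aromatic carbon, para to a large group, would shift the number beyond the scatter.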